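Replacing the triazole on the indole with a sulfonamide chain

The compounds below may be only part of what the source reports. "The series", "measured", "known", "first", "only" and "open" are said of these compounds alone.

Measured compounds in an assay on CHO cells for displacement of a labelled ligand from 5-hydroxytryptamine receptor 1D (Homo sapiens); a lower number here means a stronger inhibitor, a higher number a weaker inhibitor:
compound 1 `O[C@H]1Cc2ccccc2C1NC1CCN(CCCc2c[nH]c3ccc(-n4cnnc4)cc23)CC1` gives 37 nM
compound 2 `C[C@@H](NC1CCN(CCCc2c[nH]c3ccc(-n4cnnc4)cc23)CC1)c1ccccc1` gives 0.4 nM
compound 3 `c1ccc2c(c1)CCC2NCC1CCN(CCCc2c[nH]c3ccc(-n4cnnc4)cc23)CC1` gives 1.1 nM

Compound 2 has the lowest number of the three in this assay. Its nearest neighbour is compound 3, with a 2.8-fold higher number from compound 2 to compound 3 (0.44 log units; beyond the scatter); its furthest is compound 1, with a 93-fold lower number from compound 1 to compound 2 (1.97 log units; beyond the scatter). The third step, a 34-fold lower number from compound 1 to compound 3 (1.53 log units; beyond the scatter), also lies on the amine side of the shared core.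

Compound 4 `CNS(=O)(=O)Cc1ccc2[nH]cc(CCCN3CCC(N[C@H](C)c4ccccc4)CC3)c2c1` differs from compound 2 in one place: (methylsulfamoyl)methyl in place of 4H-1,2,4-triazol-4-yl on an aromatic carbon. None of the three measured steps touches this position; all of them exchange the group on the amine nitrogen while the triazole is kept in every measured compound. Within the data shown here, there is therefore no measured step that bears on this change, and the outlook rests only on the fact that the amine side, which carried the large steps, is unchanged between compound 2 and compound 4.

Compound 4 is expected to stay close to compound 2, with a step of a 2.0-fold higher number from compound 2 to compound 4 (0.30 log units; within the scatter) that may not go beyond the scatter, though the range is left wide. The estimate for compound 4 in this assay is 0.8 nM, between 0.15 nM and 5 nM.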

Compound 4, half-maximal inhibitory concentration: 43 nM
Compound 4: middle estimate off by 54-fold (1.73 log units), on the low side; the measured number lies above the stated range.
By their numbers in this assay, from the lowest: compound 2; then compound 3; then compounds 1 and 4 (each within the scatter of the next).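

In this assay, the group on this aromatic carbon proves to matter as much as the group on the amine nitrogen: (methylsulfamoyl)methyl in place of 4H-1,2,4-triazol-4-yl gives a 110-fold higher number from compound 2 to compound 4 (2.03 log units; beyond the scatter), a step of similar size to a 93-fold lower number from compound 1 to compound 2 (1.97 log units; beyond the scatter). Among these compounds, all the earlier compounds kept the triazole, so they could show only the amine side; this pair shows that keeping the amine side of compound 2 unchanged does not preserve its low number once the triazole is replaced. The change removes a five-membered aromatic ring and brings in an open chain with a hydrogen-bond donor, and nothing available explains the loss or separates these differences.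

As far as these compounds go, whether a carboxamide or a nitrile on this carbon would keep the low number of compound 2 remains open. From the compounds shown here alone, it is also open whether (methylsulfamoyl)methyl would carry a similar penalty alongside the ((2,3-dihydro-1H-inden-1-yl)amino)methyl group of compound 3, or whether the size of this step is particular to the amine side of compound 2.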